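Removing a Methyl From a Weak Dihydrofolate Reductase Inhibitor

The source may report more compounds than this note shows. Statements on the series, on what has been measured and on what is new or still open speak of the compounds shown alone.

Two compounds have been measured so far:
compound 1, `CC1CCc2nc(N)nc(O)c2C1`: 4.26
compound 2, `Nc1nc(S)c2cc(Sc3ccc4ccccc4c3)ccc2n1`: 6.64

Both were tested in an assay for inhibition of Dihydrofolate reductase (Homo sapiens); on this read-out lower numbers stand for lower potency and higher numbers for higher potency (the scale is a negative logarithm). Compound 1 stands lowest of the two numbers; compound 2 lies higher by a gap beyond the usual scatter, but the two structures differ in many places, so their values say nothing about any single change.

Compound 3, `Nc1nc(O)c2c(n1)CCCC2`, is the unmeasured compound. It keeps the core of compound 1 and differs from it in one place: hydrogen in place of methyl on a saturated ring carbon. Among the compounds with values here, no step between two measured compounds isolates a change of this kind, so nothing measured here sets its size. A change of one carbon on a saturated ring, away from any ring that carries the amino and hydroxy groups, is expected to move this assay little, if at all, and no step beyond the scatter is expected in either direction. The step from compound 1 to compound 3 is estimated as a number 0.16 log units lower from compound 1 to compound 3 (within the scatter).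

Compound 3 is therefore expected to give about 4.1, most likely between 3.6 and 4.6.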

Compound 3, logarithm of the reciprocal of the active concentration, log(1/C): 3.96
Beside the measured number, compound 3's estimate is 0.14 log units above it, within the range that was stated.
By their numbers in this assay, from the lowest: compounds 3 and 1 (each within the scatter of the next); then compound 2.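

Within the data shown here, replacing methyl with hydrogen on this saturated ring carbon gives a number 0.30 log units lower from compound 1 to compound 3 (within the scatter) in this assay, and this is the only step here that isolates a single change. The two compounds therefore cannot be told apart in this assay, so the methyl shows no measurable contribution at this position, although a step this small cannot rule out a slight one. Nothing available here offers an explanation for this result.

As far as these compounds go, a methyl is only a small probe, so it remains open whether a longer chain, an amine or a carboxylic acid on the same carbon would also leave the number within the scatter. From the compounds shown here alone, it is equally open whether any such group there would raise the potency of the shared core or lower it.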